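Swapping a cyano tail for a hydroxamic acid chain

A few compounds are considered here, and "the series" means these few. Any claim that something is new, unique, unknown or untested is made for them only; others in the source may bear on it.

Of the compounds shown here, three with a shared core have been tested in an assay on isolated protein for inhibition of leukotriene B4 receptor 1 (Homo sapiens), tested at 10 uM; a higher number here means more inhibition at the concentration tested (going by the name of the read-out), a lower number less inhibition. Compound 1, `CC(=O)c1cc(CC2CO2)c(OCCCCC#N)cc1O`, gives 62%. Compound 2, `C=CCc1cc(C(C)=O)c(O)cc1OCCCC#N`, gives 47%. Compound 3, `CC(=O)c1cc(C(C)(C)C)c(OCCCCCC(C)(C)C#N)cc1O`, gives 1%. Among these three numbers compound 2 stands second highest: compound 1 lies higher by a margin beyond the usual scatter, and compound 3 lies far lower, also beyond the scatter.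

The next compound, compound 4, is `C=CCc1cc(C(C)=O)c(O)cc1OCCCCCC(=O)NO`, and it has not yet been measured in this assay. The change from compound 2 to compound 4 is 2-(hydroxycarbamoyl)ethyl in place of cyano on a saturated chain carbon, three bonds along the chain from an oxygen on an aromatic ring. Cut one bond further out, the same change reads cyanomethyl to 3-(hydroxycarbamoyl)propyl.

Among the compounds with values here, no measured pair in this set shows this exact change, so the expectation rests only on the spread of the three values. A modest drop is expected, with the step of a number 9 percentage points lower from compound 2 to compound 4 (within the scatter) likely to run downward, though it may stay within the scatter. For compound 4 the estimated inhibition is 38%, expected to fall between 10% and 65%.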

Compound 4, a percentage reported as inhibition, at one concentration (the size of the read-out at that concentration, not a potency): 85%
Beside the measured number, compound 4's estimate is 47 percentage points below it, outside the stated range (above it).
By their numbers in this assay, from the lowest: compound 3; then compound 2; then compound 1; then compound 4.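

In this assay, the saturated chain carbon three bonds along the chain from an oxygen on an aromatic ring accepts a much larger group than cyano: placing 2-(hydroxycarbamoyl)ethyl there gives a number 38 percentage points higher from compound 2 to compound 4 (beyond the scatter). Within the data shown here, all three earlier compounds end in a nitrile, so compound 4 is the first here to show that a tail with another end group, a hydroxamic acid, can retain inhibition at the tested concentration, and that a nitrile is not required for it. Nothing measured here explains this rise.

The change lengthens the chain and replaces the end group in one step, so the two contributions cannot be separated. A nitrile on a chain as long as that of compound 4, or a carboxylic acid in place of the hydroxamic acid, would help to show which part carries the gain.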